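This account rests on a few compounds, and the source may have more. Where it says the series, first, only, none or still open, it means among the compounds named here.

Measured so far in a functional assay on liver (Sus scrofa) for inhibition of squalene monooxygenase (Homo sapiens), using microsomes; on this read-out lower numbers stand for stronger inhibition and higher numbers for weaker inhibition: compound 1 `CCN(C/C=C/C#CC(C)(C)C)Cc1cccc(OC[Si](C)(C)c2ccc(F)cc2)c1` gives 60 nM; compound 2 `CCN(C/C=C/C#CC(C)(C)C)Cc1cccc(OC[Si](C)(C)c2ccc(OC)cc2)c1` gives 870 nM; compound 3 `CCN(C/C=C/C#CC(C)(C)C)Cc1cccc(OC[Si](C)(C)c2cccc(C)c2)c1` gives 3000 nM.

Compound 3 stands highest of the three numbers, and both steps onto it are beyond the scatter: a 3.4-fold higher number from compound 2 to compound 3 (0.54 log units; beyond the scatter) and a 50-fold higher number from compound 1 to compound 3 (1.70 log units; beyond the scatter).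

Compound 4 `CCN(C/C=C/C#CC(C)(C)C)Cc1cccc(OC[Si](C)(C)c2ccc(C(=O)C(F)(F)F)cc2)c1` is not yet measured. Its change from compound 3 is 4-((trifluoromethyl)carbonyl)phenyl in place of 3-methylphenyl on a silicon. Going by the values given here, the two measured steps onto compound 3 both exchange the aryl group on the silicon and both run upward, so reversing that exchange points downward in this assay; the entering group has no measured counterpart, so the size is uncertain. Compound 4 is expected at 400 nM, range 80 nM to 2000 nM, an expected step of a 7.5-fold lower number from compound 3 to compound 4 (0.88 log units; beyond the scatter).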

Compound 4, half-maximal inhibitory concentration: 5000 nM
Compound 4: the middle estimate sits 13-fold (1.10 log units) below what was measured; the measured number lies above the stated range.
By their numbers in this assay, from the lowest: compound 1; then compound 2; then compounds 3 and 4 (each within the scatter of the next).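

In this assay, 4-((trifluoromethyl)carbonyl)phenyl on the silicon is not separated from 3-methylphenyl (a 1.7-fold higher number from compound 3 to compound 4 (0.22 log units; within the scatter)). With only the substituent on the aromatic carbon changed, (trifluoromethyl)carbonyl gives weaker inhibition than methoxy (a 5.7-fold higher number from compound 2 to compound 4 (0.76 log units; beyond the scatter)) and far weaker inhibition than fluoro (an 83-fold higher number from compound 1 to compound 4 (1.92 log units; beyond the scatter)), so a 4-substituted phenyl on the silicon does not by itself secure the low number of compound 1. No available data explain this difference. Open, on these data alone, is whether chloro or nitrile in place of fluoro would stay near compound 1.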